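Aryl swap on a weakly inhibiting series

A few compounds are considered here, and "the series" means these few. Any claim that something is new, unique, unknown or untested is made for them only; others in the source may bear on it.

In a functional assay on MIA PaCa-2 cells (Homo sapiens) for inhibition, read by MTT assay, with a stated time of 48 h, tested at 10 uM (on this read-out lower numbers stand for less inhibition of growth and higher numbers for more inhibition of growth at the one concentration tested), compound 1 `COc1ccc(COc2cc(O)c3c(=O)cc(C)oc3c2[C@H]2CCN(C)C[C@H]2O)cc1` gives 15% on the shared core. Compound 2 `Cc1cc(=O)c2c(O)c(CN3CCN(C(=O)OC(C)(C)C)CC3)c(O)c([C@H]3CCN(C)C[C@H]3O)c2o1` gives 6% and compound 3 `Cc1oc2c([C@H]3CCN(C)C[C@H]3O)c(O)cc(O)c2c(=O)c1C(O)c1cccc(Cl)c1` gives 2% in this assay as well. Compound 3 lies within the scatter of compound 2 and beyond the scatter under compound 1.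

The next structure is compound 4 `CCOc1ccc(Br)c(C(O)c2c(C)oc3c([C@H]4CCN(C)C[C@H]4O)c(O)cc(O)c3c2=O)c1` and the change from compound 3 is 2-bromo-5-ethoxyphenyl in place of 3-chlorophenyl on a saturated chain carbon bound to an aromatic carbon and an oxygen on a saturated carbon in one place. In words, 2-bromo-5-ethoxyphenyl stands in place of 3-chlorophenyl on a saturated chain carbon bound to an aromatic carbon and an oxygen on a saturated carbon.

Among the measured compounds shown here, no two measured compounds differ in one place only, so the data give no direct measure of a swap of this kind. The expectation rests on the measured frame alone, with compound 3 at 2% and compound 1 at 15% as its two ends. A slight rise in this assay is expected, with no step beyond the scatter. The estimated change is a number 4 percentage points higher from compound 3 to compound 4 (within the scatter) and it is expected to stay within the scatter. For compound 4 the estimated value is 6% (expected range 0% to 18%).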

Compound 4, percent growth inhibition at one concentration: 4%
Compound 4: middle estimate off by 2 percentage points, on the high side; the range from low to high includes it.
By their numbers in this assay, from the lowest: compounds 3, 4, 2 and 1 (each within the scatter of the next, the first and the last beyond it).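

In this assay, among the compounds shown here, the first comparison that differs in one place reads a number 2 percentage points higher from compound 3 to compound 4 (within the scatter) and so does not separate 2-bromo-5-ethoxyphenyl from 3-chlorophenyl on a saturated chain carbon bound to an aromatic carbon and an oxygen on a saturated carbon. This swap brings in a group with more heavy atoms, with bromine and an ethoxy group in place of chlorine, and takes the hydrogen-bond acceptors of the group from 0 to 1, yet the read-out stays within the scatter, so at this place neither the larger group nor the change of halogen shows a measurable effect at the one concentration tested. No measurement at hand bears on why the two groups read alike.

Open, on these data alone, is whether an aminophenyl or carboxyphenyl group, or a longer alkyl chain in place of the aromatic ring, would give a step beyond the scatter at this place. Also open, as far as these compounds go, is whether an amine in place of the oxygen on that carbon would change the read-out, and steps linking this pair to compound 1 or compound 2 cannot be read.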